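Chloro added to the core of the meta-substituted benzyl purine

A few compounds are considered here, and "the series" means these few. Any claim that something is new, unique, unknown or untested is made for them only; others in the source may bear on it.

Three compounds of the series have numbers in a functional assay on OVCAR-8 cells (Homo sapiens) for cytotoxicity, read by sulforhodamine B assay, with a stated time of 48 h; on this read-out higher numbers stand for weaker inhibition of growth and lower numbers for stronger inhibition of growth. Compound 1 `ClCc1ccccc1Cn1cnc2c(Cl)nc(Cl)nc21` gives 1230 nM, and compound 3 `ClCc1ccc(Cn2cnc3nc(Cl)nc(Cl)c32)cc1` gives 1990 nM. Going by the values given here, compound 2 `ClCc1cccc(Cn2cnc3c(Cl)ncnc32)c1`, the only member carrying a single chloro group on the core, gives 21900 nM, the highest of the three numbers; its gaps to compound 3 and to compound 1 both lie beyond the scatter, so compound 2 is the weakest inhibitor of growth among the measured set.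

Compound 4 `ClCc1cccc(Cn2cnc3c(Cl)nc(Cl)nc32)c1` has not been measured in this assay. It differs from compound 2 by chloro in place of hydrogen on an aromatic carbon, which brings the core of compound 4 to the same two-chloro substitution pattern as compound 1 and compound 3. Among the compounds with values here, no directly comparable step between measured compounds exists. The expectation is a step from compound 2 to compound 4 of an 11-fold lower number from compound 2 to compound 4 (1.04 log units; beyond the scatter), toward stronger inhibition of growth, because compound 1 at 1230 nM and compound 3 at 1990 nM both carry the two-chloro core. For compound 4 the estimate is 2000 nM, with a range from 700 nM to 6000 nM.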

Compound 4, concentration for 50% growth inhibition: 1820 nM
Beside the measured number, compound 4's estimate is 1.1-fold (0.04 log units) above it; low and high end bracket the measured number.
By their numbers in this assay, from the lowest: compounds 1, 4 and 3 (each within the scatter of the next); then compound 2.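

In this assay, going by these compounds alone, chloro in place of hydrogen on the aromatic carbon between two ring nitrogen atoms gives a 12-fold lower number from compound 2 to compound 4 (1.08 log units; beyond the scatter) toward stronger inhibition of growth, the first step that can be read between compounds differing in one place. This carbon is therefore not indifferent to substitution: the entry of one heavy atom there goes with a large change, beyond the scatter. No available data bear on the reason for this step.

Whether the step is particular to chloro stays open, since the compounds shown carry only hydrogen or chloro on this carbon; an amine or a methoxy group there would test this. As far as these compounds go, whether a step of this size holds with the chloromethyl group elsewhere on the benzyl ring also stays open, since this pair is the only one that can be read.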